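Phenoxy for chloro on the pendant aryl of compound 1

The source may hold more compounds than are shown below. What is called first, only, known or untested is meant among the compounds shown, and "the series" means these compounds.

Compound 1 `CC1=C(C(=O)Nc2ccc(F)c(Cl)c2)C(c2cccc(Cl)c2)NC(=S)N1` is the reference point of the series. For the measured compounds named here, in a functional assay on COLO 205 cells (Homo sapiens) for cytotoxicity, read by sulforhodamine B assay, with a stated time of 48 h (a higher number here means a weaker inhibitor of growth, a lower number a stronger inhibitor of growth), compound 1 gives 4170 nM, the lower of the two numbers measured so far. Going by the values given here, compound 2 `CC1=C(C(=O)Nc2ccc(F)c(Cl)c2)C(c2ccccc2Cl)NC(=S)N1` in this assay gives 24000 nM; the step of a 5.8-fold higher number from compound 1 to compound 2 (0.76 log units; beyond the scatter) is the only measured step in the set, and it concerns where the chloro sits rather than what the substituent is. Compound 3 `CC1=C(C(=O)Nc2ccc(F)c(Cl)c2)C(c2cccc(Oc3ccccc3)c2)NC(=S)N1` has not been measured. Relative to compound 1 the change is phenoxy in place of chloro on an aromatic carbon. Among the compounds with values here, no measured step exchanges the substituent itself, so the precedent bears only loosely: it shows that the aryl group on the saturated ring carbon matters to the read-out, without indicating a direction for a phenoxy. The expected step is therefore a 1.2-fold higher number from compound 1 to compound 3 (0.08 log units; within the scatter), which is within the scatter, with wide uncertainty on both sides. Compound 3 is estimated at 5000 nM, with a range from 1200 nM to 20000 nM.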

Compound 3, concentration for 50% growth inhibition: 17800 nM
For compound 3 the middle estimate is 3.6-fold (0.55 log units) below the measured one; the range from low to high includes it.
By their numbers in this assay, from the lowest: compound 1; then compounds 3 and 2 (each within the scatter of the next).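

In this assay, for the compounds shown here, the step of a 4.3-fold higher number from compound 1 to compound 3 (0.63 log units; beyond the scatter) is the first measured exchange of the substituent itself, rather than of its place on the pendant aryl. At this aromatic carbon, meta to a large group, chloro gives the lower number, and phenoxy with its additional six-membered aromatic ring costs only a modest step, so the position accepts a far larger group while growth inhibition remains measurable. Nothing available accounts for the size or direction of this step.

As far as these compounds go, whether methoxy, an amine or a carboxylic acid at this carbon would match or improve on chloro remains open. Also open, from the compounds shown here alone, is whether phenoxy would follow the same trend on the aromatic carbon that carries chloro in compound 2.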